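Maximal response in a chlorocarboxyphenyl ether pair

The source may hold more compounds than are shown below. What is called first, only, known or untested is meant among the compounds shown, and "the series" means these compounds.

Measured so far:
compound 1 `Cc1c(OCCCCOc2cccc(C(=O)O)c2)ccc(C(=O)CC2CCCC2)c1O`: 92.9%
compound 2 `Cc1c(OCCCCOc2ccc(C(=O)O)c(Cl)c2)ccc(C(=O)CC2CCCC2)c1O`: 40%
compound 3 `Cc1c(OCCCCOc2cccc(C(=O)O)c2)ccc(C(=O)CC2CCCC2)c1C`: 16.5%

All three numbers come from an assay on HEK293 cells for positive allosteric modulation of metabotropic glutamate receptor 3 (Rattus norvegicus), read by thallium flux, with a stated time of 2.5 min; on this read-out lower numbers stand for smaller maximal responses and higher numbers for larger maximal responses. Compound 1 gives 92.9%, the highest of the three. The change 4-carboxy-3-chlorophenyl in place of 3-carboxyphenyl on an oxygen on a saturated carbon leads to compound 2 with 40%, a step of a number 52.9 percentage points lower from compound 1 to compound 2 (beyond the scatter). The two cores differ by methyl in place of hydroxy on an aromatic carbon; compound 3 stands at 16.5%, a step of a number 76.4 percentage points lower from compound 1 to compound 3 (beyond the scatter), and it is the lowest of the three measured numbers, beyond the scatter from both others.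

Compound 4 `Cc1c(OCCCCOc2ccc(C(=O)O)c(Cl)c2)ccc(C(=O)CC2CCCC2)c1C` has not been measured. For the measured compounds named here, it differs from compound 3 by 4-carboxy-3-chlorophenyl in place of 3-carboxyphenyl on an oxygen on a saturated carbon, the same change as the one between compound 1 and compound 2, and the place is described in the same words for both pairs. Going by the values given here, the only measured instance of this change, from compound 1 to compound 2, was large. Nothing here shows how that change behaves on the core of compound 3, and a maximal response cannot fall far below the number already reached by compound 3.

Compound 4 is expected to give about 8%, most likely between 0% and 25%, in this assay. That estimate means an expected step of a number 8.5 percentage points lower from compound 3 to compound 4 (within the scatter), smaller than the earlier one because compound 3 at 16.5% leaves little room below it.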

Compound 4, largest response reached (reported as percent of maximum), in percent of the reference or control that the assay uses: 35.5%
For compound 4 the middle estimate is 27.5 percentage points below the measured one; the whole stated range lies below it.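

On the core of compound 3, the exchange to 4-carboxy-3-chlorophenyl gives a number 19 percentage points higher from compound 3 to compound 4 (beyond the scatter) in this assay, so the change does not carry over in size or direction from the core of compound 1: the same change on two cores in this assay, a number 52.9 percentage points lower (beyond the scatter) from compound 1 to compound 2 and a number 19 percentage points higher (beyond the scatter) from compound 3 to compound 4, 71.9 percentage points apart, beyond the scatter of two such steps.

Methyl in place of hydroxy on an aromatic carbon likewise depends on its partner group, with a number 4.5 percentage points lower from compound 2 to compound 4 (within the scatter) on the 4-carboxy-3-chlorophenyl ether, far from its step on the 3-carboxyphenyl ether: the same change on two cores in this assay, a number 76.4 percentage points lower (beyond the scatter) from compound 1 to compound 3 and a number 4.5 percentage points lower (within the scatter) from compound 2 to compound 4, 71.9 percentage points apart, beyond the scatter of two such steps.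

These notes rest on one set of four compounds and one read-out, so they show that the two changes do not add up here, but not how the exchange would behave on any other core, nor what lies behind the difference.

Going by these compounds, it remains open which part of the exchange counts, the added chlorine or the different place of the carboxylic acid on the ring. Also open, on these data alone, is whether a tetrazole or an amide in place of the carboxylic acid, or a shorter or longer chain in the ether linker, would show the same dependence on the hydroxy or methyl of the core.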